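Replacing a pyridinylmethyl arm with isobutyl on compound 1

The compounds below may be only part of what the source reports. "The series", "measured", "known", "first", "only" and "open" are said of these compounds alone.

Within the data shown here, compound 1 `Cc1csc2cc([C@H](C)Nc3ncnc(N)c3C#N)c(-c3cccc(CN4CCC(CN(C)Cc5ccccn5)CC4)c3)c(=O)n12` is one of two compounds measured in an ADME assay on the whole organism (lung, Rattus norvegicus) for metabolic stability, read by LC-MS (on this read-out lower numbers stand for a shorter-lived compound and higher numbers for a longer-lived compound), and in this assay compound 1 gives 10.9 h, the higher of the two numbers. The other is compound 2 `Cc1csc2cc([C@H](C)Nc3ncnc(N)c3C#N)c(Cc3cccc(CN(C)CC(C)C)c3)c(=O)n12`, which in this assay gives 2.3 h, a gap beyond the usual scatter. Compound 3 `Cc1csc2cc([C@H](C)Nc3ncnc(N)c3C#N)c(-c3cccc(CN4CCC(CN(C)CC(C)C)CC4)c3)c(=O)n12` has not yet been measured. It differs from compound 1 in one place: isopropyl in place of pyridin-2-yl on a saturated chain carbon bound to an amine nitrogen. Among the measured compounds shown here, no pair of measured compounds isolates this change, and compound 2, which also carries an isobutyl(methyl)amino group, differs from compound 1 in other ways too, so its value offers only a loose hint. The step of a 2.0-fold lower number from compound 1 to compound 3 (0.30 log units; within the scatter) is expected to be downward and probably beyond the scatter, though smaller than the gap to compound 2. For compound 3 a half-life of about 5.5 h is estimated, with a likely range from 2.5 h to 11 h.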

Compound 3, half-life in the lung assay: 12 h
The estimate for compound 3 lay 2.2-fold (0.34 log units) below the measured number; the whole stated range lies below it.
By their numbers in the lung assay, from the lowest: compound 2; then compounds 1 and 3 (each within the scatter of the next).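

In the lung assay, isopropyl in place of pyridin-2-yl on a saturated chain carbon bound to an amine nitrogen comes with a 1.1-fold higher number from compound 1 to compound 3 (0.04 log units; within the scatter), so at this position the half-life does not depend on keeping the aromatic ring. In a physicochemical assay for acid dissociation, compound 1 gives 7 and compound 3 gives 8. The swap therefore changes how readily the proton is given up, while the half-life stays within the scatter, so in this pair the two read-outs do not move together: the measured acid dissociation constant of compound 1, 7, and of compound 3, 8, a number 1.00 log units higher (beyond the scatter)

Among these compounds, with only two groups compared at this position, it remains open whether a plain phenyl ring or a hydroxyl-bearing chain would also leave the half-life in this range. One pair also cannot show whether the two read-outs stay apart for other groups here.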